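Removing a methoxy group: from compound 2 to compound 4

This account rests on a few compounds, and the source may have more. Where it says the series, first, only, none or still open, it means among the compounds named here.

Measured compounds:
- compound 1, `COc1cc(C(=O)/C=C/c2cc(-c3cc(OC)c(OC)c(OC)c3)n3nc(-c4ccccc4)cc3n2)cc(OC)c1OC`, 34900 nM
- compound 2, `COc1ccc(-c2cc(/C=C/C(=O)c3cc(OC)c(OC)c(OC)c3)nc3cc(-c4ccccc4)nn23)cc1OC`, 8300 nM
- compound 3, `COc1ccc(/C=C/C(=O)c2cc(-c3ccc(OC)c(OC)c3)n3nc(-c4ccccc4)cc3n2)cc1`, 14900 nM

In a functional assay on DU-145 cells (Homo sapiens) for antiproliferative activity, read by MTT assay, with a stated time of 24 h (a lower number here means a stronger inhibitor, a higher number a weaker inhibitor), compound 2 has the lowest number of the three. Its gap to compound 3 is within the scatter, so the two cannot be ranked against each other. Compound 1 stands further away: a 4.2-fold lower number from compound 1 to compound 2 (0.62 log units; beyond the scatter), a change made by hydrogen in place of methoxy on an aromatic carbon of the ring attached to the shared core.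

Compound 4, `COc1ccc(C(=O)/C=C/c2cc(-c3ccc(OC)c(OC)c3)n3nc(-c4ccccc4)cc3n2)cc1OC`, is the next compound. Compared with compound 2 it carries hydrogen in place of methoxy on an aromatic carbon. Among the measured compounds shown here, this is the same kind of change as the one from compound 1 to compound 2, but placed on the other aromatic ring, the one joined to the carbonyl. For the measured compounds named here, only that one step bears on it; the data hold no step on this ring itself, so its size can only be guessed from the other ring, where removing a methoxy lowered the number modestly.

Compound 4 is therefore expected to give an estimate of 12000 nM in this assay, within a range of 4000 nM to 40000 nM, meaning an expected step of a 1.4-fold higher number from compound 2 to compound 4 (0.16 log units; within the scatter), which would be no change beyond the scatter.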

Compound 4, half-maximal inhibitory concentration: 7200 nM
The estimate for compound 4 lay 1.7-fold (0.22 log units) above the measured number; the measured number falls inside the stated range.
By their numbers in this assay, from the lowest: compounds 4, 2 and 3 (each within the scatter of the next, the first and the last beyond it); then compound 1.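

In this assay, a 1.2-fold lower number from compound 2 to compound 4 (0.06 log units; within the scatter): on the ring joined to the carbonyl, going from 3,4,5-trimethoxyphenyl to 3,4-dimethoxyphenyl leaves the number where repeated measurements could not tell the two compounds apart. Among the compounds shown here, the same swap on the other ring, a 4.2-fold lower number from compound 1 to compound 2 (0.62 log units; beyond the scatter), lay beyond the scatter, and only this second step shows that in these compounds, losing a methoxy group does not have the same outcome on both rings. Nothing measured here explains the contrast between the two rings.

The compounds shown leave open what a hydroxyl, an amine or a chlorine would do in place of this methoxy group, as hydrogen is the only replacement seen at this position. They also leave open whether taking away a further methoxy group from the 3,4-dimethoxyphenyl ring of compound 4 would move the number, or whether this ring would stay just as tolerant of the change.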